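The source may report more compounds than this note shows. Statements on the series, on what has been measured and on what is new or still open speak of the compounds shown alone.

Measured so far: compound 1 `CC(C)OCc1nc(Nc2ccc(C(F)(F)F)cc2)c2ccc(-c3ncccc3C(F)(F)F)cc2n1` gives 0.3 nM in a functional assay for antagonist activity at transient receptor potential cation channel subfamily V member 1 (Homo sapiens); on this read-out higher numbers stand for weaker inhibition and lower numbers for stronger inhibition; compound 2 `CS(=O)(=O)CCc1nc(Nc2ccc(C(F)(F)F)cc2)c2ccc(-c3ncccc3C(F)(F)F)cc2n1` gives 36 nM.

Compound 1 stands with the lowest of the two numbers. Compound 3 `FC(F)(F)c1ccc(Nc2nc(CN3CCN(C4CCCC4)CC3)nc3cc(-c4ncccc4C(F)(F)F)ccc23)cc1` differs from compound 1 by 4-cyclopentylpiperazin-1-yl in place of isopropoxy on a saturated chain carbon bound to an aromatic carbon. Within the data shown here, the only measured step at this same position is a 120-fold higher number from compound 1 to compound 2 (2.08 log units; beyond the scatter), a large one, and it is the sole guide here. By analogy, a loss for compound 3 is expected, though of uncertain size, as the entering group differs from that of compound 2. The step from compound 1 to compound 3 is estimated as a 20-fold higher number from compound 1 to compound 3 (1.30 log units; beyond the scatter). Compound 3 is expected to give 6 nM, within 0.6 nM to 60 nM.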

Compound 3, half-maximal inhibitory concentration: 8 nM
Compound 3: the middle estimate sits 1.3-fold (0.12 log units) below what was measured; the measured number falls inside the stated range.
By their numbers in this assay, from the lowest: compound 1; then compound 3; then compound 2.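

At this saturated chain carbon bound to an aromatic carbon, the larger 4-cyclopentylpiperazin-1-yl also falls short of isopropoxy, with a 27-fold higher number from compound 1 to compound 3 (1.43 log units; beyond the scatter) in this assay and thus a second large step. The two replacements are not equivalent, as a 4.5-fold lower number from compound 2 to compound 3 (0.65 log units; beyond the scatter) shows, so the size of the loss depends on the entering group. Nothing measured accounts for either step.

From the compounds shown here alone, whether methoxy or an unsubstituted piperazin-1-yl at this place would come closer to compound 1 stays open.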